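The source may hold more compounds than are shown below. What is called first, only, known or untested is meant among the compounds shown, and "the series" means these compounds.

Compound 1 `CN(C)c1ccc(CN(Cc2ccc(C(C)(C)C)cc2)Cc2cc3cc(Br)ccc3[nH]c2=O)cc1` gives in a toxicity assay on MDCK cells (Canis lupus familiaris) for cytotoxicity, read by crystal violet staining, with a stated time of 48 h (on this read-out higher numbers stand for lower toxicity in this test and lower numbers for higher toxicity in this test), a value that is only a limit of the test, > 10000 nM.
Compound 2 `CC(c1ccc(N(C)C)c(Cl)c1)N(Cc1ccc(C(C)(C)C)cc1)Cc1cc2cc(Br)ccc2[nH]c1=O` gives in this assay 6100 nM.

For the measured compounds named here, compound 2 therefore holds the only real number measured here, while the other compound sits at the limit of > 10000 nM in this assay, at which 1 of the 2 values shown sits. Going by the values given here, the single measured step, an at least 1.6-fold lower number from compound 1 to compound 2 (0.21 log units; that floor lies within the scatter), exchanges the group on the amine nitrogen and leaves the 4-(tert-butyl)benzyl part untouched. Compound 3 `CC(c1ccc(N(C)C)c(Cl)c1)N(Cc1ccc(OC(F)(F)F)cc1)Cc1cc2cc(Br)ccc2[nH]c1=O` changes exactly that untouched part: trifluoromethoxy in place of tert-butyl on an aromatic carbon. Among the compounds with values here, no measured step speaks to an exchange of this kind, so nothing in the data points to a shift beyond the usual scatter in either direction. Compound 3 is thus expected to show a 1.0-fold lower number from compound 2 to compound 3 (0.01 log units; within the scatter). Compound 3 is estimated at 6000 nM in this assay, with a likely range from 2500 nM to 15000 nM.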

Compound 3, half-maximal cytotoxic concentration: 4700 nM
For compound 3 the middle estimate is 1.3-fold (0.11 log units) above the measured one, within the range that was stated.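

In this assay, putting trifluoromethoxy in place of tert-butyl on an aromatic carbon, para to a large group, gives a 1.3-fold lower number from compound 2 to compound 3 (0.11 log units; within the scatter). For the compounds shown here, this is the first measured change to this part of the molecule, and it shows that a group of carbon only and a group holding oxygen and fluorine cannot be told apart here when the rest of the structure stays the same. No measurement shown here gives a cause for this result.

Still open, from the compounds shown here alone, is how this position would read with a plain hydrogen, an amine or a carboxylic acid in place of these two groups. Also open, going by these compounds, is whether the same exchange would read alike with the 4-(dimethylamino)benzyl group of compound 1 on the amine nitrogen.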